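Adding a chloro group to compound 1

The compounds below may be only part of what the source reports. "The series", "measured", "known", "first", "only" and "open" are said of these compounds alone.

Compound 1 `CCn1c(-c2ccccc2)nn(C)c1=S`: 1.2 mg/kg
Compound 2 `Cn1nc(-c2ccccc2)n(C)c1=S`: 0.13 mg/kg

In a functional assay on the whole organism with Mus musculus as the target (on this read-out higher numbers stand for an effect only at larger amounts of compound and lower numbers for an effect already at smaller amounts), compound 1 has the higher of the two numbers, so its effect needs the larger dose. Compound 3 `CCn1c(-c2ccc(Cl)cc2)nn(C)c1=S` keeps the core of compound 1 with one change: chloro in place of hydrogen on an aromatic carbon. Within the data shown here, the only measured step, a 9.2-fold lower number from compound 1 to compound 2 (0.97 log units; beyond the scatter), was modest and lay elsewhere, on a saturated chain carbon bound to an aromatic nitrogen. It therefore says nothing direct about this change, and the range must stay wide. Expected is no change at the digits printed from compound 1 to compound 3 (within the scatter), with no step beyond the scatter in either direction. For compound 3 the estimated value is 1.2 mg/kg, with an expected range of 0.3 mg/kg to 5 mg/kg.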

Compound 3, dose for half-maximal effect: 21.2 mg/kg
Compound 3: middle estimate off by 18-fold (1.25 log units), on the low side; the measured number lies above the stated range.
By their numbers in this assay, from the lowest: compound 2; then compound 1; then compound 3.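

In this assay, chloro in place of hydrogen on an aromatic carbon gives an 18-fold higher number from compound 1 to compound 3 (1.25 log units; beyond the scatter) and so counts as a large step. Among these compounds, the six-membered aromatic ring, unchanged between the earlier compounds, thus proves sensitive at this place: one added chlorine atom means that a much larger dose is needed for the half-maximal effect. Nothing at hand explains this shift. Still open, going by these compounds, is whether the shift belongs to chloro alone, or whether a methoxy group or an amine at this place would raise the number as well.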